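A few compounds are considered here, and "the series" means these few. Any claim that something is new, unique, unknown or untested is made for them only; others in the source may bear on it.

Among the compounds with values here, in a functional assay on SW982 cells (Homo sapiens) for inhibition, read by MTT assay, with a stated time of 72 h (a lower number here means a stronger inhibitor, a higher number a weaker inhibitor), compound 1 `COc1cc(OC)c(OC)cc1/C=C/C(=O)c1ccc(Cl)cc1` gives 58500 nM, which is the only exact number available so far. Compound 2 `COc1cc(OC)c(-c2cc(=O)c3cc(Cl)ccc3o2)cc1OC` is reported only as a limit, > 150000 nM. Compound 1 is therefore a weak inhibitor on a scale with few reference points, and it serves as the starting point here. Compound 3 `COc1cc(OC)c(OC)cc1/C=C/C(=O)c1cc(Cl)ccc1O` keeps the rest of compound 1 and changes one group, with 5-chloro-2-hydroxyphenyl in place of 4-chlorophenyl on a carbonyl carbon. Within the data shown here, no measured pair shows what this swap does, so the expectation stays anchored to compound 1 at 58500 nM. The expected change is small, probably no larger than the usual scatter and leaning slightly towards stronger inhibition, an estimated 1.5-fold lower number from compound 1 to compound 3 (0.17 log units; within the scatter). For compound 3 the expected value is 40000 nM, with an estimated range from 12000 nM to 130000 nM.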

Compound 3, half-maximal inhibitory concentration: > 150000 nM
Compound 3 was reported as a limit; the forecaster's own chance of this, stated with the estimate: 15%; middle value at least 3.7-fold (0.57 log units) from the limit.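

Within the data shown here, this is the first measured step at this position, on a carbonyl carbon, and it gives an at least 2.5-fold higher number from compound 1 to compound 3 (0.40 log units; beyond the scatter) in this assay, with 5-chloro-2-hydroxyphenyl in place of 4-chlorophenyl. Among these compounds, the swap therefore weakens inhibition rather than strengthening it, a direction that no earlier pair could show. The step gives only a minimum and not a full size, since compound 3 is known only through a limit: the limit of > 150000 nM in this assay, at which 2 of the 3 values shown sit.

The swap adds a hydroxyl and also changes the chlorine's numbered place in the group's name, and the compounds shown do not separate these two changes. Also open, on these data alone, is how an amine or a carboxylic acid on this ring would behave, and whether any group here could bring inhibition clearly below the level of compound 1.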